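Swapping the styryl aryl ring in a weak chalcone series

This account rests on a few compounds, and the source may have more. Where it says the series, first, only, none or still open, it means among the compounds named here.

Compound 1, `COc1cccc(/C=C/C(=O)c2sc(Nc3cccc(C)c3)nc2C)c1`, in a functional assay on PC-3 cells (Homo sapiens) for cytotoxicity, read by MTT assay (a lower number here means a stronger inhibitor, a higher number a weaker inhibitor), shows > 25000 nM.
Compound 2, `COc1cccc(/C=C/C(=O)c2sc(Nc3ccccc3)nc2C)c1`, in this assay shows > 25000 nM.

Both of these numbers are limits of the assay rather than measured values. Among the measured compounds shown here, compound 1 thus stands only at a limit, and the one other value shown stands at the same place, both sitting at the limit of > 25000 nM in this assay, at which 2 of the 2 values shown sit. For the measured compounds named here, the only measured step, a step that the two limits leave unreadable from compound 1 to compound 2, has a limit at each end and so has no readable size or direction.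

Compound 3, `Cc1cccc(Nc2nc(C)c(C(=O)/C=C/c3ccccc3Cl)s2)c1`, differs from compound 1 by 2-chlorophenyl in place of 3-methoxyphenyl on a double-bonded chain carbon bound to a double-bonded chain carbon. Going by the values given here, no measured step touches this ring, and the single step that exists gives no size to lean on. Nothing in the two values shown argues for compound 3 leaving the limit, so compound 3 is expected to give 30000 nM, within the range 10000 nM to 100000 nM. The expected step that the limit leaves unreadable from compound 1 to compound 3 is estimated to be none beyond the scatter.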

Compound 3, half-maximal inhibitory concentration: 22200 nM
The estimate for compound 3 lay 1.4-fold (0.13 log units) above the measured number; low and high end bracket the measured number.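

Among the compounds shown here, compound 3 is the first compound here to give a measured number rather than a limit in this assay: it reads 22200 nM with 2-chlorophenyl at this position. The change from 3-methoxyphenyl amounts to an at least 1.1-fold lower number from compound 1 to compound 3 (0.05 log units; that floor lies within the scatter), so this step cannot be told apart from no change at all. The series therefore remains weak, with most of its values still at the limit: the limit of > 25000 nM in this assay, at which 2 of the 3 values shown sit.

The compounds shown leave open whether a different group on this ring, such as an amine or a carboxylic acid, would shift the number clearly beyond the scatter. They also leave open how a plain phenyl ring or a 3-chlorophenyl ring would read, and so the chlorine and its place on the ring cannot be judged separately.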